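Working notes: from compound 3 to compound 4

The source may hold more compounds than are shown below. What is called first, only, known or untested is meant among the compounds shown, and "the series" means these compounds.

In a physicochemical assay for lipophilicity (a higher number here means a more lipophilic compound, a lower number a more polar compound), compound 3 (`C[C@H]1CC[C@@H]2[C@@H](OC(=O)[C@]23CC(c2c(Cl)cccc2Cl)N(c2ccccc2)O3)[C@]2(C)C(=O)C=C[C@@]12O`) gives 4.45 and stands highest of the three measured compounds. Compound 2 (`Cc1ccc(C2C[C@@]3(ON2c2ccccc2)C(=O)O[C@@H]2[C@H]3CC[C@H](C)[C@]3(O)C=CC(=O)[C@@]23C)cc1`) gives 3.64 in the same read-out, and compound 1 (`C[C@H]1CC[C@@H]2[C@@H](OC(=O)[C@]23CC(c2c(Cl)cccc2Cl)=NO3)[C@]2(C)C(=O)C=C[C@@]12O`) gives 2.67 as the lowest number of the three.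

Compound 4 (`C[C@H]1CC[C@@H]2[C@@H](OC(=O)[C@]23CC(c2ccccc2F)N(c2ccccc2)O3)[C@]2(C)C(=O)C=C[C@@]12O`) has not been measured yet. The change is 2-fluorophenyl in place of 2,6-dichlorophenyl on a saturated ring carbon and it sits on a saturated ring carbon of a five-membered non-aromatic ring, next to the ring nitrogen.

For the measured compounds named here, one measured step bears on it, at this same ring carbon: a number 0.81 log units higher from compound 2 to compound 3 (beyond the scatter) with 2,6-dichlorophenyl in place of 4-methylphenyl. Compound 4 gives up that same 2,6-dichlorophenyl, so a fall of similar, modest size is expected, running the opposite way to that step. Going by the values given here, the match is only partial, as 2-fluorophenyl is not 4-methylphenyl and no measured compound carries it. The expected step is a number 0.90 log units lower from compound 3 to compound 4 (beyond the scatter) and it should lie beyond the scatter.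

In this assay the estimate for compound 4 is 3.55 with 3.15 to 3.95 as the expected range.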

Compound 4, partition coefficient: 3.35
Compound 4: middle estimate off by 0.20 log units, on the high side; measured number inside the range.
By their numbers in this assay, from the lowest: compound 1; then compounds 4 and 2 (each within the scatter of the next); then compound 3.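

Notes on compound 4: in this assay, three aryl groups can now be compared at this saturated ring carbon, and 2-fluorophenyl in place of 2,6-dichlorophenyl gives a number 1.10 log units lower from compound 3 to compound 4 (beyond the scatter), a step marked as large, whereas the earlier step at this carbon was marked as modest. Against 4-methylphenyl at the same carbon, 2-fluorophenyl gives a number 0.29 log units lower from compound 2 to compound 4 (within the scatter), so of these three compounds sharing the core and the phenyl group on the ring nitrogen, compound 3 alone stands apart from the other two, while compound 2 and compound 4 cannot be separated. No measurement on hand gives a reason why the compound with 2,6-dichlorophenyl separates from the other two.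

The compounds shown leave open whether the separation of compound 3 needs both chlorine atoms, as neither 2-chlorophenyl nor unsubstituted phenyl stands at this carbon in any of them. They also leave open how far the number would fall with a phenyl ring carrying an amine or a carboxylic acid here, and whether 2-fluorophenyl would give a similar step in the core of compound 1.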